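The source may hold more compounds than are shown below. What is called first, only, known or untested is meant among the compounds shown, and "the series" means these compounds.

Measured so far in a functional assay on MGC-803 cells (Homo sapiens) for inhibition, read by sulforhodamine B assay; a higher number here means a weaker inhibitor, a lower number a stronger inhibitor:
compound 1, `O=C1C(Nc2ccc(I)cc2)=CC(=O)c2c1nc1n2[C@H]2OC[C@@H](O)[C@H]2OC1`, gives 2150 nM
compound 2, `Cc1ccc(NC2=CC(=O)c3c(nc4n3[C@H]3OC[C@@H](O)[C@H]3OC4)C2=O)cc1`, gives 1550 nM
compound 3, `COc1ccccc1NC1=CC(=O)c2nc3n(c2C1=O)[C@H]1OC[C@@H](O)[C@H]1OC3`, gives 1630 nM

Compound 3 holds the second highest of the three numbers. Its nearest neighbour is compound 2, whose value sits within the scatter of it, and compound 1 is the furthest, also within the scatter. Among the measured compounds shown here, the only single-point step among the measured compounds is a 1.4-fold lower number from compound 1 to compound 2 (0.14 log units; within the scatter), which stays within the scatter. For the measured compounds named here, no step connects compound 2 and compound 3 directly; their two values simply lie close to each other.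

Compound 4 is `O=C1C=C(Nc2cccc(Cl)c2)C(=O)c2c1nc1n2[C@H]2OC[C@@H](O)[C@H]2OC1`. Against compound 3 the change is 3-chlorophenyl in place of 2-methoxyphenyl on an amine nitrogen. Going by the values given here, none of the measured steps covers this exact exchange. Among the compounds with values here, the one step that does alter the group on the amine nitrogen, a 1.4-fold lower number from compound 1 to compound 2 (0.14 log units; within the scatter), moved the number by less than the scatter, and the three measured values span a range that is itself within the scatter. On that basis the step is expected to be a 1.1-fold higher number from compound 3 to compound 4 (0.04 log units; within the scatter), with no change beyond the scatter in either direction. Compound 4 is therefore estimated at 1800 nM in this assay, with a range from 900 nM to 3600 nM.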

Compound 4, half-maximal inhibitory concentration: 1770 nM
Compound 4: the middle estimate sits 1.0-fold (0.01 log units) above what was measured, within the range that was stated.
By their numbers in this assay, from the lowest: compounds 2, 3, 4 and 1 (each within the scatter of the next).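

In this assay the exchange of 2-methoxyphenyl for 3-chlorophenyl on the amine nitrogen gives a 1.1-fold higher number from compound 3 to compound 4 (0.04 log units; within the scatter) and so stays inside the scatter, although it replaces the whole aryl group, with a different substituent at a different ring position. The earlier step, a 1.4-fold lower number from compound 1 to compound 2 (0.14 log units; within the scatter), only swapped one substituent on an aromatic carbon, so this result extends the tolerance seen at this amine nitrogen from that narrow swap to an exchange of an oxygen-bearing aryl group for a chlorine-bearing one, within these compounds only. Nothing at hand bears on why the number holds across this change.

The compounds shown do not separate the identity of a substituent from its ring position, as no pair keeps one group and moves it, for example a 2-chlorophenyl group against a 3-chlorophenyl group. As far as these compounds go, it also stays open whether the number would hold with a non-aromatic group on the amine nitrogen, such as cyclohexyl or a longer alkyl chain, or with a phenyl ring carrying a carboxylic acid or an amine.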